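The source may report more compounds than this note shows. Statements on the series, on what has been measured and on what is new or still open speak of the compounds shown alone.

Compound 3 `CN(C)CCCNC(=O)CCC(=O)OCCCCCCSc1ccc([N+](=O)[O-])c2nonc12` stands lowest of the three measured numbers in an assay on isolated protein for inhibition of glutathione S-transferase P (Homo sapiens), with a stated time of 10 min (on this read-out higher numbers stand for weaker inhibition and lower numbers for stronger inhibition), where compound 3 gives 160 nM. Compound 1 `O=C(CCC(=O)OCCCCCCSc1ccc([N+](=O)[O-])c2nonc12)Nc1ccc(F)cc1` gives 8570 nM in this assay, and compound 2 `O=C(CCC(=O)OCCCCCCSc1ccc([N+](=O)[O-])c2nonc12)Nc1ccc(C(F)(F)F)cc1` gives 5050 nM. The step of a 1.7-fold lower number from compound 1 to compound 2 (0.23 log units; within the scatter) lies within the scatter. By contrast, the steps of a 54-fold lower number from compound 1 to compound 3 (1.73 log units; beyond the scatter) and a 32-fold lower number from compound 2 to compound 3 (1.50 log units; beyond the scatter) are both large and beyond the scatter, so the 3-(dimethylamino)propyl amide stands clearly apart from the two aryl amides.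

Compound 4 `CCN(CC)CCCNC(=O)CCC(=O)OCCCCCCSc1ccc([N+](=O)[O-])c2nonc12` is not yet measured. It differs from compound 3 in one place: diethylamino in place of dimethylamino on a saturated chain carbon, three bonds along the chain from an amide-type nitrogen. Going by the values given here, none of the measured steps bears directly on this change. Among the compounds with values here, the two large steps replace an aryl group on the amide-type nitrogen with the 3-(dimethylamino)propyl chain, and the small step exchanges one substituent on an aromatic carbon for another; no pair among compounds 1 to 3 compares dimethylamino with diethylamino. The change from compound 3 to compound 4 keeps the chain, the amide and the acceptor count, and alters only the two groups on the nitrogen at its end.

Compound 4 is therefore expected to give about 170 nM in this assay, with a range from 60 nM to 500 nM. The expected step of a 1.1-fold higher number from compound 3 to compound 4 (0.03 log units; within the scatter) stays within the scatter, with no clear direction.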

Compound 4, half-maximal inhibitory concentration: 9550 nM
The estimate for compound 4 lay 56-fold (1.75 log units) below the measured number, outside the stated range (above it).
By their numbers in this assay, from the lowest: compound 3; then compounds 2, 1 and 4 (each within the scatter of the next).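

In this assay, going by these compounds alone, the change at the end of the chain, which no earlier pair compared, turns out to matter greatly: diethylamino in place of dimethylamino, on a saturated chain carbon, three bonds along the chain from an amide-type nitrogen, gives a 60-fold higher number from compound 3 to compound 4 (1.78 log units; beyond the scatter). The clear separation of the 3-(dimethylamino)propyl amide from the two aryl amides does not carry over to the 3-(diethylamino)propyl amide, with the steps of a 1.9-fold higher number from compound 2 to compound 4 (0.28 log units; within the scatter) and a 1.1-fold higher number from compound 1 to compound 4 (0.05 log units; within the scatter) both remaining within the scatter, so a dialkylamino propyl chain alone does not set compound 3 apart. No evidence is at hand on why these two groups differ so much.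

The compounds shown leave open whether a methylamino group, a primary amine, a pyrrolidine or a morpholine at this place, or a shorter or longer chain leading to the amine, would stay close to compound 3 at 160 nM. Also open, from the compounds shown here alone, is whether an ethyl(methyl)amino group, which combines one substituent from each of the two amines, would fall nearer to compound 3 or to compound 4.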